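Adding a Hydroxy Group to the Phenyl Ring of Compound 3

The compounds below may be only part of what the source reports. "The series", "measured", "known", "first", "only" and "open" are said of these compounds alone.

Compound 1 `N#Cc1c(Cl)nc(SCC(=O)Nn2c(COc3ccc(Cl)cc3Cl)nc3ccccc3c2=O)nc1-c1ccccc1`: 60%
Compound 2 `N#Cc1c(Nc2ccc(Cl)cc2)nc(SCC(=O)Nn2c(COc3ccc(Cl)cc3Cl)nc3ccccc3c2=O)nc1-c1ccccc1`: 54.6%
Compound 3 `N#Cc1c(Nc2ccc(O)cc2)nc(SCC(=O)Nn2c(COc3ccc(Cl)cc3Cl)nc3ccccc3c2=O)nc1-c1ccccc1`: 72.7%

In a functional assay on the whole organism (strain albino) for inhibition, with Rattus norvegicus as the target, read by paw edema, with a stated time of 1 h, at a dose of 100 mg/kg by the oral route (a lower number here means less inhibition, a higher number more inhibition at the dose given (going by the name of the read-out)), compound 3 stands highest of the three, with the steps of a number 12.7 percentage points higher from compound 1 to compound 3 (beyond the scatter) and a number 18.1 percentage points higher from compound 2 to compound 3 (beyond the scatter) both beyond the scatter, while a number 5.4 percentage points lower from compound 1 to compound 2 (within the scatter) lies within it. Compound 4 `N#Cc1c(Nc2ccc(O)cc2)nc(SCC(=O)Nn2c(COc3ccc(Cl)cc3Cl)nc3ccccc3c2=O)nc1-c1ccc(O)cc1` differs from compound 3 by hydroxy in place of hydrogen on an aromatic carbon. Within the data shown here, no measured step touches this position, so the nearest guide is the change in which a hydroxy group also entered, which lifted the value from compound 2 to compound 3. On that basis a small rise is expected, a number 3.3 percentage points higher from compound 3 to compound 4 (within the scatter), though it may well fall within the scatter. Compound 4 is therefore estimated at 76%, with a range from 62% to 88%.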

Compound 4, a percentage reported as inhibition, in the whole organism at one dose (the size of the read-out at that dose, not a potency): 86.4%
Beside the measured number, compound 4's estimate is 10.4 percentage points below it; low and high end bracket the measured number.
By their numbers in this assay, from the lowest: compounds 2 and 1 (each within the scatter of the next); then compound 3; then compound 4.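

Among these compounds, changing phenyl to 4-hydroxyphenyl gives a number 13.7 percentage points higher from compound 3 to compound 4 (beyond the scatter) in this assay, so this ring, the same in the earlier compounds, also influences the read-out. This gain adds to the earlier one from hydroxy in place of chloro on the other aromatic ring, a number 18.1 percentage points higher from compound 2 to compound 3 (beyond the scatter), so a hydroxy group raises the number at both places. No measurement available here explains the rise. The compounds shown leave open whether a methoxy group, an amine or a carboxylic acid at this place would serve as well as hydroxy. They also leave open what a hydroxy group would do elsewhere on this ring.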